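Methyl for Methoxy on a Weakly Active Triazole Analogue

The source may report more compounds than this note shows. Statements on the series, on what has been measured and on what is new or still open speak of the compounds shown alone.

Compound 1 `C=C1C[C@]23C[C@@]1(O)CC[C@@H]2c1cccc(C)c1[C@@H]3Cn1cc(-c2ccc(OC)cc2)nn1` gives > 20000 nM in a functional assay on MCF7 cells (Homo sapiens) for cytotoxicity, read by MTT assay, with a stated time of 4 days; on this read-out lower numbers stand for stronger inhibition and higher numbers for weaker inhibition.
Compound 2 `C=C1C(=O)[C@]23C[C@@]1(O)CC[C@H]2c1ccc(O)c(C)c1[C@@H]3Cn1cc(-c2ccc(F)cc2)nn1` gives 1700 nM in this assay.

The value for compound 1 is a limit of the assay rather than a number, as the limit of > 20000 nM in this assay, at which 1 of the 2 values shown sits, records. Among the compounds with values here, compound 2 differs from compound 1 at several places at once, so no single step can be drawn between them; its value only shows that a compound of this core can reach a measurable number in this assay.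

Compound 3 `C=C1C[C@]23C[C@@]1(O)CC[C@@H]2c1cccc(C)c1[C@@H]3Cn1cc(-c2ccc(C)cc2)nn1` differs from compound 1 in one place: methyl in place of methoxy on an aromatic carbon. No measured step of this kind exists among the compounds shown, so the expectation rests on compound 1 alone. Because compound 1 sits at the limit of > 20000 nM in this assay, at which 1 of the 2 values shown sits, compound 3 is expected to stay near that limit, and the step that the limit leaves unreadable from compound 1 to compound 3 is expected to fall within the scatter. Compound 3 is therefore estimated at 30000 nM, with a range from 8000 nM to 100000 nM.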

Compound 3, half-maximal inhibitory concentration: > 20000 nM
Compound 3 ended at the assay's limit (the forecaster's own chance of this, stated with the estimate: 70%); the middle value is on the limit's open side.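

Compound 1 and compound 3 both end at a limit of this assay rather than at a number, so no step can be read between them: the limit of > 20000 nM in this assay, at which 2 of the 3 values shown sit.

The compounds shown leave open whether methyl in place of methoxy changes cytotoxicity at all, as neither compound 1 nor compound 3 gives a number to compare.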